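This account rests on a few compounds, and the source may have more. Where it says the series, first, only, none or still open, it means among the compounds named here.

Compound 1 `c1cncc(-c2nc3ccccc3n2C2CC2)c1` was studied in an assay on V79 cells for inhibition of cytochrome P450 11B2, mitochondrial (Homo sapiens), read by HTRF, with a stated time of 1 h (a higher number here means a weaker inhibitor, a lower number a stronger inhibitor), where compound 1 gives 49 nM. Two compounds built on a different core were measured alongside it; how the two cores differ is not broken down here. Compound 3 `N#Cc1cc2c(cc1F)nc(-c1cccnc1)n2C1CC1` gives 0.6 nM, and compound 2 `N#Cc1cc2c(cc1F)nc(-c1cncc(F)c1)n2C1CC1` gives 1 nM. The change from compound 3 to compound 2 is fluoro in place of hydrogen on an aromatic carbon, and it made a 1.7-fold higher number from compound 3 to compound 2 (0.22 log units; within the scatter).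

Compound 4 `Fc1ccc2nc(-c3cccnc3)n(C3CC3)c2c1` is not yet measured. It differs from compound 1 by fluoro in place of hydrogen on an aromatic carbon, the same kind of change, though here on a six-membered aromatic ring of carbon only, part of a fused system, rather than on a ring with one nitrogen two atoms from the ring nitrogen. Because the earlier step was a 1.7-fold higher number from compound 3 to compound 2 (0.22 log units; within the scatter), the step from compound 1 to compound 4 is expected to be similarly small, a 1.2-fold lower number from compound 1 to compound 4 (0.09 log units; within the scatter). Compound 4 is thus estimated at 40 nM, between 15 nM and 110 nM.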

Compound 4, half-maximal inhibitory concentration: 4 nM
For compound 4 the middle estimate is 10-fold (1.00 log units) above the measured one, and the stated range ends above it.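

In this assay, fluoro in place of hydrogen on an aromatic carbon gave a 12-fold lower number from compound 1 to compound 4 (1.09 log units; beyond the scatter), and the size of this step did not carry over from the earlier example. The two steps differ: the same change on two cores in this assay, a 1.7-fold higher number (0.22 log units; within the scatter) from compound 3 to compound 2 and a 12-fold lower number (1.09 log units; beyond the scatter) from compound 1 to compound 4, 20-fold (1.31 log units) apart, beyond the scatter of two such steps

This shows that, in this series, the step measured on one core did not predict the step on the other, but it does not show what sets them apart, as the fluoro also sits on a different ring in each pair. The compounds shown leave open how another group, such as chloro, methoxy or an amine, would behave at that place on the core of compound 1. They also leave open whether fluoro on the same ring of both cores would give steps of like size.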